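Acyl change from compound 3 to compound 4 in this series

This account rests on a few compounds, and the source may have more. Where it says the series, first, only, none or still open, it means among the compounds named here.

Measured so far. Compound 1 `CC(C)(C)OC(=O)N1CCC(OC2CCCC(Oc3ccc(S(C)(=O)=O)cc3)C2)CC1` sits at the assay limit in a functional assay on isolated protein for agonist activity at Glucose-dependent insulinotropic receptor (Homo sapiens), read by HTRF and cAMP accumulation; on this read-out lower numbers stand for an effect already at smaller amounts and higher numbers for an effect only at larger amounts of compound: > 100000 nM. Compound 2 `CC(C)(C)OC(=O)N1CCC(O[C@H]2CC[C@H](Oc3ccc(S(C)(=O)=O)nn3)CC2)CC1` gives 651 nM. Compound 3 `C[C@H](CF)OC(=O)N1CCC(O[C@H]2CC[C@H](Oc3cnc(S(C)(=O)=O)cn3)CC2)CC1` gives 36.8 nM.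

Compound 3 holds the lowest of the two numbers; compound 2 lies beyond the scatter above it, and compound 1 is a limit only, as noted in the limit of > 100000 nM in this assay, at which 1 of the 3 values shown sits.

Compound 4 `CS(=O)(=O)c1cnc(O[C@H]2CC[C@H](OC3CCN(C(=O)C4(C(F)(F)F)CCCC4)CC3)CC2)cn1` differs from compound 3 by a group of 9 heavy atoms (6 carbon, 3 fluorine; one five-membered non-aromatic ring of carbon only) in place of a group of 5 heavy atoms (3 carbon, 1 oxygen, 1 fluorine; no ring), on a carbonyl carbon. Among the measured compounds shown here, no pair of measured compounds covers a change of this kind, so no measured step guides it. The expected step of a 1.1-fold higher number from compound 3 to compound 4 (0.04 log units; within the scatter) is taken as none beyond the scatter. Compound 4 is therefore estimated at 40 nM, with a range of 10 nM to 200 nM.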

Compound 4, half-maximal effective concentration: 38.4 nM
Compound 4: middle estimate off by 1.0-fold (0.02 log units), on the high side; the measured number falls inside the stated range.
By their numbers in this assay, from the lowest: compounds 3 and 4 (each within the scatter of the next); then compound 2. At a limit, above all of these: compound 1.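

In this assay, the group of 9 heavy atoms, with its five-membered non-aromatic ring of carbon only, replaces the group of 5 heavy atoms on the carbonyl carbon with a step within the scatter: a 1.0-fold higher number from compound 3 to compound 4 (0.02 log units; within the scatter). This position therefore tolerates a ring-bearing group that lacks the hydrogen-bond acceptor and defined stereocentre of the group it replaces. No measured property bears on this step, so its origin stays unresolved.

Open, going by these compounds, is how this assay responds to an amine or a carboxylic acid on this carbonyl carbon. Also open, on these data alone, is whether a six-membered ring of carbon keeps the number.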